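A few compounds are considered here, and "the series" means these few. Any claim that something is new, unique, unknown or untested is made for them only; others in the source may bear on it.

In a functional assay on HeLa cells (Homo sapiens) for antiproliferative activity, read by MTT assay, with a stated time of 24 h (a higher number here means a weaker inhibitor, a lower number a stronger inhibitor), compound 1 (`O=S(=O)(c1ccc(F)cc1)n1c(-c2cn(-c3ccccc3)nc2-c2ccc(F)cc2)nc2ccccc21`) gives 2440 nM, compound 2 (`Cc1ccc(C)c(S(=O)(=O)n2c(-c3cn(-c4ccccc4)nc3-c3ccc(C(F)(F)F)cc3)nc3ccccc32)c1`) gives 210 nM and compound 3 (`O=[N+]([O-])c1ccc(S(=O)(=O)n2c(-c3cn(-c4ccccc4)nc3-c3ccc(C(F)(F)F)cc3)nc3ccccc32)cc1`) gives 950 nM. Compound 3 therefore stands in the middle of the three, with the second highest number.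

Compound 4 (`O=S(=O)(c1ccc(F)cc1)n1c(-c2cn(-c3ccccc3)nc2-c2ccc(C(F)(F)F)cc2)nc2ccccc21`) has not yet been measured. It is compound 3 with fluoro in place of nitro on an aromatic carbon, para to a large group, so that 4-nitrophenyl becomes 4-fluorophenyl: fluoro in place of nitro on an aromatic carbon.

Among the measured compounds shown here, one measured step bears directly on this position: a 4.5-fold higher number from compound 2 to compound 3 (0.66 log units; beyond the scatter), a modest change on swapping 2,5-dimethylphenyl for 4-nitrophenyl on the sulfonyl sulfur. It shows that this group can move the number, but it says nothing about fluoro. The (4-fluorophenyl)sulfonyl group of compound 4 also occurs in compound 1, at 2440 nM, but that compound differs elsewhere as well, so it offers no clean comparison.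

With no firm direction available, the estimate means a 1.1-fold higher number from compound 3 to compound 4 (0.02 log units; within the scatter), an expected step within the scatter. For compound 4 the estimated value is 1000 nM, with an expected range of 350 nM to 2800 nM.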

Compound 4, half-maximal inhibitory concentration: 2190 nM
The estimate for compound 4 lay 2.2-fold (0.34 log units) below the measured number; the measured number falls inside the stated range.
By their numbers in this assay, from the lowest: compound 2; then compound 3; then compounds 4 and 1 (each within the scatter of the next).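

In this assay, fluoro in place of nitro on an aromatic carbon gives a 2.3-fold higher number from compound 3 to compound 4 (0.36 log units; beyond the scatter), so this position distinguishes the two groups, and 4-fluorophenyl sits further from 2,5-dimethylphenyl, with a 10-fold higher number from compound 2 to compound 4 (1.02 log units; beyond the scatter), than 4-nitrophenyl does. With the (4-fluorophenyl)sulfonyl group held constant, trifluoromethyl in place of fluoro on an aromatic carbon gives a 1.1-fold lower number from compound 1 to compound 4 (0.05 log units; within the scatter), so this swap does not separate the two compounds. No measurement here offers an explanation for these steps.

Going by these compounds, it remains open how a methoxy or an amino group in place of fluoro at this position would read. Also open, on these data alone, are which methyl of the 2,5-dimethylphenyl group matters and whether the trifluoromethyl swap would behave the same way with that group on the sulfonyl sulfur.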